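The compounds below may be only part of what the source reports. "The series", "measured", "known", "first", "only" and "open" are said of these compounds alone.

Measured so far in a functional assay on SR cells (Homo sapiens) for inhibition, read by sulforhodamine B assay, with a stated time of 48 h, tested at 0.1 uM; a higher number here means a weaker effect of the compound at the concentration tested, a lower number a stronger effect:
compound 1, `O=C(Nc1cccc(-n2cc(-c3ccncc3)c(-c3cc(O)cc(Cl)c3)n2)c1)Nc1ccc(Cl)c(C(F)(F)F)c1`, gives 98%
compound 2, `COc1cc(Cl)cc(-c2nn(-c3cccc(NC(=O)Nc4cc(C(F)(F)F)cc(C(F)(F)F)c4)c3)cc2-c2ccncc2)c1`, gives 92%

Compound 2 holds the lowest of the two numbers in this assay, and its nearest neighbour is compound 1, whose value is higher by an amount that lies within the scatter; the two compounds therefore cannot be told apart on these numbers, and both leave most of the activity intact at the concentration tested.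

Compound 3, `COc1cc(Cl)cc(-c2nn(-c3cccc(NC(=O)Nc4cccc(C(F)(F)F)c4)c3)cc2-c2ccncc2)c1`, has not been measured. It differs from compound 2 in one place: hydrogen in place of trifluoromethyl on an aromatic carbon. Trifluoromethyl leaves and hydrogen enters, on an aromatic carbon of a six-membered aromatic ring of carbon only, meta to a trifluoromethyl group.

Going by the values given here, no step between measured compounds is available, so there is no recorded size for such a change. With both measured compounds sitting high in this assay, the working expectation is that the change leaves compound 3 in the same region, with no step beyond the scatter; if anything, a slight drift upward. The step from compound 2 to compound 3 is estimated at a number 3 percentage points higher from compound 2 to compound 3 (within the scatter). Compound 3 is expected to give about 95%, within 80% to 105%, pending the measurement.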

Compound 3, a percentage reported as activity, at one concentration (the size of the read-out at that concentration, not a potency): 93%
Estimate against measurement, compound 3: 2 percentage points above; measured number inside the range.
By their numbers in this assay, from the lowest: compounds 2, 3 and 1 (each within the scatter of the next).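

Going by these compounds alone, the step of a number 1 percentage points higher from compound 2 to compound 3 (within the scatter) in this assay is the first recorded size for hydrogen in place of trifluoromethyl on an aromatic carbon, meta to a trifluoromethyl group. At this position, removing a trifluoromethyl group of 4 heavy atoms does not separate the pair: compound 3 reads 93% and stays as high in the assay as compound 2, so at this single concentration the two groups cannot be told apart. Nothing measured beyond these read-outs bears on the result, and no explanation can be drawn from it.

The compounds shown leave open whether a different group at this position, such as an amine, a carboxylic acid or a longer chain, would give a step beyond the scatter. They also leave open what happens when the remaining trifluoromethyl group of compound 3 is replaced by hydrogen, and whether compound 2 and compound 3 would separate at a higher concentration, where the read-out is not so close to the top of its range.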